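This account rests on a few compounds, and the source may have more. Where it says the series, first, only, none or still open, it means among the compounds named here.

Values so far in a functional assay on KB cells (Homo sapiens) for inhibition, read by sulforhodamine B assay; on this read-out higher numbers stand for weaker inhibition of growth and lower numbers for stronger inhibition of growth
- compound 1 `Cc1ccc2[nH]c(-c3ccc(-c4ccc(-c5ccc(N(C)C)cc5)cc4)cc3)nc2c1` gives 6240 nM
- compound 2 `Cc1ccc2[nH]c(-c3ccc(-c4ccc(-c5cccc(Cl)c5)cc4)cc3)nc2c1` gives 2260 nM

Compound 2 holds the lower of the two numbers at 2260 nM and compound 1 is its nearest neighbour. The move to compound 3 `COc1ccc(-c2ccc(-c3ccc(-c4nc5cc(C)ccc5[nH]4)cc3)cc2)cc1OC` puts 3,4-dimethoxyphenyl in place of 3-chlorophenyl on an aromatic carbon, para to a large group (3,4-dimethoxyphenyl in place of 3-chlorophenyl on an aromatic carbon). Among the measured compounds shown here, only one measured step bears on this place (a 2.8-fold lower number from compound 1 to compound 2 (0.44 log units; beyond the scatter)) and it was modest. Like compound 1, compound 3 carries a substituted phenyl without chlorine, so a partial return toward the value of compound 1 (6240 nM) is the working expectation. For the measured compounds named here, this is thin support, since it rests on one step and no measured compound carries a methoxy group. The expected change in this assay is a small rise (a 1.7-fold higher number from compound 2 to compound 3 (0.23 log units; within the scatter)) that is smaller than the measured step and may stay within the scatter. For compound 3 the estimated value is 3800 nM with an expected range from 1500 nM to 9500 nM in this read-out.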

Compound 3, concentration for 50% growth inhibition: 2190 nM
Compound 3: middle estimate off by 1.7-fold (0.24 log units), on the high side; the range from low to high includes it.
By their numbers in this assay, from the lowest: compounds 3 and 2 (each within the scatter of the next); then compound 1.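

In this assay, the replacement of 3-chlorophenyl by 3,4-dimethoxyphenyl gives a 1.0-fold lower number from compound 2 to compound 3 (0.01 log units; within the scatter), so these two groups cannot be told apart at this position, although the entering group has 10 heavy atoms and 2 hydrogen-bond acceptors and the leaving group has 7 heavy atoms and 0 hydrogen-bond acceptors. Chlorine is therefore not required for the lower number seen against compound 1: the replacement of 4-(dimethylamino)phenyl by the chlorine-free 3,4-dimethoxyphenyl gives a 2.8-fold lower number from compound 1 to compound 3 (0.45 log units; beyond the scatter), a step of the same size as a 2.8-fold lower number from compound 1 to compound 2 (0.44 log units; beyond the scatter), which leaves compound 1 apart from both others. No evidence bearing on the reason for these steps is available in the data at hand.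

Open, as far as these compounds go, is whether the higher number of compound 1 follows from the dimethylamino group itself or from the ring position it occupies, a question that 3-(dimethylamino)phenyl and 4-chlorophenyl would separate. Also open, from the compounds shown here alone, is how far this position tolerates groups of another kind, such as an unsubstituted phenyl, a carboxylic acid on the ring or a morpholine.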